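The source may report more compounds than this note shows. Statements on the series, on what has been measured and on what is new or still open speak of the compounds shown alone.

Compound 1 `N=C(NO)N/N=C/c1ccc(O)cc1`: in an ADME assay on Vero cells (Chlorocebus sabaeus) for cytotoxicity (on this read-out lower numbers stand for higher toxicity in this test and higher numbers for lower toxicity in this test), compound 1 gives > 100000 nM, a limit of the test rather than a number.
Compound 2 `N/C(=N\O)N/N=C/c1ccccc1O`: in this assay compound 2 gives > 100000 nM, again a limit.

So compound 1 stands at the edge of what this assay can report; the limit of > 100000 nM in this assay, at which 2 of the 2 values shown sit, shows that both values shown sit there. Compound 3 `Cc1ccc(/C=N/NC(=N)NO)cc1` differs from compound 1 by methyl in place of hydroxy on an aromatic carbon. Among the measured compounds shown here, no measured pair shows what this change does, so no direction beyond the scatter is expected. Compound 3 is estimated at 120000 nM, from 40000 nM to 400000 nM, a step that the limit leaves unreadable from compound 1 to compound 3 that is expected to be within the scatter.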

Compound 3, half-maximal cytotoxic concentration: > 100000 nM
Compound 3 gave a limit, no number (the forecaster's own chance of this, stated with the estimate: 75%); the middle value does not contradict the limit.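

No step can be read from compound 1 to compound 3, since each gives only a limit, not a number: the limit of > 100000 nM in this assay, at which 3 of the 3 values shown sit. The compounds shown leave open whether methyl in place of hydroxy on an aromatic carbon changes anything in this assay.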